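Moving the ring nitrogen: compound 3 to compound 4

This account rests on a few compounds, and the source may have more. Where it says the series, first, only, none or still open, it means among the compounds named here.

Measured compounds:
- compound 1, `CC(C)n1nc(-c2cc(-c3ccccc3)on2)c(C(N)=O)c1N`: 236 nM
- compound 2, `Cc1ccc(-c2cc(-c3nn(C(C)C)c(N)c3C(N)=O)no2)cc1`: 1660 nM
- compound 3, `CC(C)n1nc(-c2cc(-c3cccnc3)on2)c(C(N)=O)c1N`: 3400 nM

All three were tested in an assay on isolated protein for inhibition of proto-oncogene tyrosine-protein kinase receptor Ret (Homo sapiens), read by radiometric assay and 33P incorporation, in the presence of a further agent that is not named here; on this read-out higher numbers stand for weaker inhibition and lower numbers for stronger inhibition. Compound 3 stands at the top of these numbers, which here means the weakest inhibition; its nearest neighbour is compound 2, reached by a 2.0-fold higher number from compound 2 to compound 3 (0.31 log units; beyond the scatter), and the furthest is compound 1, reached by a 14-fold higher number from compound 1 to compound 3 (1.16 log units; beyond the scatter).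

Compound 4, `CC(C)n1nc(-c2cc(-c3ccccn3)on2)c(C(N)=O)c1N`, keeps every atom of compound 3 and changes only how the six-membered ring is attached: pyridin-2-yl in place of pyridin-3-yl on an aromatic carbon. The group sits on an aromatic carbon of a five-membered aromatic ring with one nitrogen and one oxygen, next to the ring oxygen.

Among the compounds with values here, none of the measured steps moves the ring nitrogen of the pyridine; they swap phenyl for 4-methylphenyl or for pyridin-3-yl, with the large step of a 14-fold higher number from compound 1 to compound 3 (1.16 log units; beyond the scatter) and the modest steps of a 7.0-fold higher number from compound 1 to compound 2 (0.85 log units; beyond the scatter) and a 2.0-fold higher number from compound 2 to compound 3 (0.31 log units; beyond the scatter). So the step to compound 4 is expected to be of modest size in this assay, its direction uncertain, with a slight lean toward a lower number since compound 3 already stands at the weak end.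

Compound 4 is therefore estimated at 2200 nM, within 500 nM to 9000 nM, an expected step of a 1.5-fold lower number from compound 3 to compound 4 (0.19 log units; within the scatter).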

Compound 4, half-maximal inhibitory concentration: 4800 nM
Compound 4: middle estimate off by 2.2-fold (0.34 log units), on the low side; low and high end bracket the measured number.
By their numbers in this assay, from the lowest: compound 1; then compound 2; then compounds 3 and 4 (each within the scatter of the next).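

In this assay, moving the ring nitrogen so that pyridin-2-yl replaces pyridin-3-yl gives a 1.4-fold higher number from compound 3 to compound 4 (0.15 log units; within the scatter), so this position does not distinguish between these two attachments of the pyridine ring. The earlier compounds shown here showed the cost of replacing phenyl with only one pyridine; the second pyridine now gives a 20-fold higher number from compound 1 to compound 4 (1.31 log units; beyond the scatter), so both attachments tested fall well short of plain phenyl, while replacing 4-methylphenyl gives a 2.9-fold higher number from compound 2 to compound 4 (0.46 log units; beyond the scatter), a smaller change that is still beyond the scatter. No supporting measurement bears on this result.

The compounds shown leave open whether the remaining attachment, pyridin-4-yl, would behave like these two pyridines or come closer to phenyl. Also open, from the compounds shown here alone, is whether a group other than methyl on the phenyl ring, such as a fluorine, a methoxy or an amine, would raise the number as methyl does in compound 2 or leave it near that of compound 1.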